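Methoxy for Amino on the Aryl Ketone of Compound 1

The source may hold more compounds than are shown below. What is called first, only, known or untested is meant among the compounds shown, and "the series" means these compounds.

Of the compounds shown here, three sharing one core have been tested in a functional assay on OVCAR-5 cells (Homo sapiens) for cytotoxicity, read by sulforhodamine B assay, with a stated time of 48 h, tested at 100 uM; a lower number here means a stronger effect, a higher number a weaker effect of the compound at the concentration tested. Compound 1 `COc1cc(-c2cc(/C=C/C(=O)c3ccc(N)cc3)[nH]n2)cc(OC)c1OC` gives -66%, the highest of the three numbers. Compound 3 `COc1ccc(-c2cc(/C=C/C(=O)c3cc(OC)c(OC)c(OC)c3)[nH]n2)cc1OC` gives -70%, which lies within the scatter of compound 1. Compound 2 `COc1ccc(-c2cc(/C=C/C(=O)c3ccc(OC)c(OC)c3)[nH]n2)cc1` gives -87%, a number beyond the scatter below compound 1, so compound 2 shows the stronger effect of that pair.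

Compound 4 `COc1ccc(C(=O)/C=C/c2cc(-c3cc(OC)c(OC)c(OC)c3)n[nH]2)cc1` has not yet been measured in this assay. It differs from compound 1 in one place: methoxy in place of amino on an aromatic carbon. The new group sits on an aromatic carbon of a six-membered aromatic ring of carbon only, para to a large group, so that a 4-aminophenyl becomes a 4-methoxyphenyl.

Among the compounds with values here, no step between two measured compounds differing in a single place is available, so the expectation for compound 4 rests on the compounds above. Both compound 2 and compound 3, which carry methoxy groups on their rings, give numbers at or below that of compound 1, though compound 3 stays within its scatter. The step from compound 1 to compound 4 is therefore expected to be a number 10 percentage points lower from compound 1 to compound 4 (within the scatter), a move toward a lower number of modest size. Compound 4 is estimated to give -76% in this assay, with a range from -95% to -57%.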

Compound 4, a percentage reported as activity, at one concentration (the size of the read-out at that concentration, not a potency): -59%
For compound 4 the middle estimate is 17 percentage points below the measured one, and the stated range covers the measured number.
By their numbers in this assay, from the lowest: compound 2; then compounds 3, 1 and 4 (each within the scatter of the next, the first and the last beyond it).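

Within the data shown here, compound 1 and compound 4 form the first pair in this set that differs in a single place, so the exchange of amino for methoxy on an aromatic carbon, para to a large group, can now be read directly. In this assay, the step is a number 7 percentage points higher from compound 1 to compound 4 (within the scatter), so this read-out does not separate the 4-aminophenyl from the 4-methoxyphenyl on this core, even though the hydrogen-bond donor of the amino group leaves with the change. Nothing available explains why the two compounds read alike.

On these data alone, what remains open is whether this position accepts other kinds of group just as readily: a hydroxyl, a carboxylic acid, a dimethylamino group or a longer chain such as ethoxy could each give a number beyond the scatter of compound 1. As far as these compounds go, it also remains open whether amino and methoxy would read alike on the different ring substitution of compound 2, and whether the same holds at lower concentrations, where a single reading at one concentration gives no guide.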